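Sugar-linked peptide series: fluorinated sugar on the linear chain

This account rests on a few compounds, and the source may have more. Where it says the series, first, only, none or still open, it means among the compounds named here.

Measured so far:
compound 1 `N=C(N)NCCC[C@@H]1NC(=O)[C@H](CSCc2cn(CCO[C@@H]3O[C@H](CF)[C@@H](O)[C@H](O)[C@H]3O)nn2)NC(=O)[C@H](Cc2ccccc2)NC(=O)[C@H](CC(=O)O)NC(=O)CNC1=O` — 148000 nM
compound 2 `N=C(N)NCCC[C@H](N)C(=O)NCC(=O)N[C@@H](CC(=O)O)C(=O)N[C@@H](CSCc1cn(CCO[C@@H]2O[C@H](CO)[C@H](O)[C@H](O)[C@H]2O)nn1)C(=O)O` — 23000 nM
compound 3 `NC(N)=NCCC[C@H](N)C(=O)NCC(=O)N[C@@H](CC(=O)O)C(=O)N[C@@H](CS)C(=O)O` — 322000 nM

All three numbers come from a functional assay on a cell-free system (Platelet, plasma, Homo sapiens) for inhibition, with a stated time of 10 min, at 37 degrees C; on this read-out lower numbers stand for stronger inhibition and higher numbers for weaker inhibition. Compound 2 has the lowest number of the three; compound 1 sits well beyond the scatter above it, and compound 3, the bare peptide without the triazole-linked sugar, is furthest away, also beyond the scatter. Within the data shown here, no pair among the measured compounds differs in only one place, so no single change has yet been isolated.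

Compound 4 `N=C(N)NCCC[C@H](N)C(=O)NCC(=O)N[C@@H](CC(=O)O)C(=O)N[C@@H](CSCc1cn(CCO[C@@H]2O[C@H](CF)[C@@H](O)[C@H](O)[C@H]2O)nn1)C(=O)O` is the next entry. It keeps the linear chain of compound 2 and changes only the sugar: a group of 11 heavy atoms (6 carbon, 4 oxygen, 1 fluorine; one six-membered non-aromatic ring with 1 hetero atom) in place of a group of 11 heavy atoms (6 carbon, 5 oxygen; one six-membered non-aromatic ring with 1 hetero atom), on an oxygen on a saturated carbon Compound 1 carries the same fluorinated sugar, but on the cyclic core, so its number cannot be read as the effect of the sugar alone.

Among the measured compounds shown here, with no isolated step to lean on, the expectation for the move from compound 2 to compound 4 in this assay is a small step, if any, probably toward a somewhat higher number, and possibly none beyond the scatter. The estimated step of a 1.4-fold higher number from compound 2 to compound 4 (0.14 log units; within the scatter) reflects this. Compound 4 is expected to give about 32000 nM, within a range of 11000 nM to 95000 nM.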

Compound 4, half-maximal inhibitory concentration: 66000 nM
Compound 4: the middle estimate sits 2.1-fold (0.31 log units) below what was measured, and the stated range covers the measured number.
By their numbers in this assay, from the lowest: compound 2; then compound 4; then compound 1; then compound 3.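

Among these compounds, this is the first isolated change: in this assay, exchanging the 3,4,5-trihydroxy-6-(hydroxymethyl)oxan-2-yl group for the fluorine-bearing sugar on the linear chain gives a 2.9-fold higher number from compound 2 to compound 4 (0.46 log units; beyond the scatter), so the number at this position depends on the make-up of the sugar and not just on its presence. The step is modest but beyond the scatter, and the two drawn structures differ both in fluorine replacing the hydroxyl of the hydroxymethyl arm and in the configuration of one ring hydroxyl, so it cannot be assigned to fluorine alone. No measurement on hand explains why the number moves with this change.

Open, as far as these compounds go, is which of the two sugar differences carries the step, a question that a sugar with the ring configuration of compound 2 and a fluoromethyl arm, or one with an aminomethyl or methoxymethyl arm, would address. Also open, from the compounds shown here alone, is whether the same sugar exchange moves the number by a similar amount on the core of compound 1, since only the fluorine-bearing sugar appears on that core here.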